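Amide Aryl Variation in Quinoline Piperazines Against Breast Cells

A few compounds are considered here, and "the series" means these few. Any claim that something is new, unique, unknown or untested is made for them only; others in the source may bear on it.

The measured compounds are:
compound 1, `CCN1CCN(c2cc(C)c3cc(NC(=O)c4cccc(Cl)c4)ccc3n2)CC1`, 3820 nM;
compound 2, `CCN1CCN(c2cc(C)c3cc(NC(=O)c4ccccc4C)ccc3n2)CC1`, 10900 nM;
compound 3, `CCc1ccccc1C(=O)Nc1ccc2nc(N3CCN(CC)CC3)cc(C)c2c1`, 15800 nM.

All three share one core and differ only in the aryl group on the carbonyl carbon. In a functional assay on MCF7 cells (Homo sapiens) for antiproliferative activity, read by MTT assay, with a stated time of 72 h (a higher number here means a weaker inhibitor, a lower number a stronger inhibitor), compound 3 gives the highest number of the three; compound 2 lies nearest, and the gap a 1.4-fold higher number from compound 2 to compound 3 (0.16 log units; within the scatter) is within the scatter, while compound 1 is furthest, the step of a 4.1-fold higher number from compound 1 to compound 3 (0.62 log units; beyond the scatter) being beyond it.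

Compound 4, `CCN1CCN(c2cc(C)c3cc(NC(=O)c4ccc(OC)cc4)ccc3n2)CC1`, is not yet measured. The change from compound 3 is 4-methoxyphenyl in place of 2-ethylphenyl on a carbonyl carbon.

Going by the values given here, the steps that bear on this are the aryl swaps a 2.9-fold higher number from compound 1 to compound 2 (0.46 log units; beyond the scatter) and a 4.1-fold higher number from compound 1 to compound 3 (0.62 log units; beyond the scatter), both modest and both running toward higher numbers when 3-chlorophenyl is exchanged for 2-methylphenyl or 2-ethylphenyl. The 4-methoxyphenyl group has no direct precedent among these compounds, so the direction is uncertain; compound 4 is expected to sit between compound 3 and compound 1, giving a step of a 2.4-fold lower number from compound 3 to compound 4 (0.39 log units; beyond the scatter) in this assay. The estimate for compound 4 is 6500 nM, within 2000 nM to 20000 nM.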

Compound 4, half-maximal inhibitory concentration: 7690 nM
Compound 4: middle estimate off by 1.2-fold (0.07 log units), on the low side; the measured number falls inside the stated range.
By their numbers in this assay, from the lowest: compounds 1, 4, 2 and 3 (each within the scatter of the next, the first and the last beyond it).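

In this assay, going by these compounds alone, 4-methoxyphenyl is the first group on this carbonyl carbon to carry a hydrogen-bond acceptor, and the swap from 2-ethylphenyl gives a 2.1-fold lower number from compound 3 to compound 4 (0.31 log units; beyond the scatter) as a modest change. The same group cannot be told apart from the other two aryl groups, since a 1.4-fold lower number from compound 2 to compound 4 (0.15 log units; within the scatter) and a 2.0-fold higher number from compound 1 to compound 4 (0.30 log units; within the scatter) both stay inside the scatter. Within the data shown here, the acceptor therefore brings compound 4 no separation from compound 1 or compound 2, and only the step from compound 3 is readable. Nothing measured here explains that step.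

The compounds leave open whether the step from compound 3 comes from losing the 2-ethylphenyl group or from gaining the 4-methoxyphenyl group. They also leave open how an amine or a carboxylic acid on this aryl ring would read out.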